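The source may hold more compounds than are shown below. What is called first, only, known or untested is meant among the compounds shown, and "the series" means these compounds.

Working notes on the series. For the measured compounds named here, all numbers so far come from a functional assay on SMMC-7721 cells (Homo sapiens) for antiproliferative activity, read by MTT assay, with a stated time of 48 h; on this read-out lower numbers stand for stronger inhibition and higher numbers for weaker inhibition. Compound 1 `O=C(/C=C/c1ccc(Oc2cc(=O)oc3ccccc23)cc1)/C=C/c1cccnc1` gives 33400 nM. Compound 2 `COc1cc(OC)c2c(=O)c(OCCCOc3ccccc3/C=C/C(=O)/C=C/c3ccccn3)c(-c3cc(OC)c(OC)c(OC)c3)oc2c1` gives 3180 nM. Compound 3 `COc1cc(OC)c2c(=O)c(OCCCOc3ccccc3/C=C/C(=O)/C=C/c3cccc([N+](=O)[O-])c3)c(-c3cc(OC)c(OC)c(OC)c3)oc2c1` gives 9200 nM, which places compound 3 second highest of the three numbers, closer to compound 2 than to compound 1. Going by the values given here, the only measured step that changes one place is a 2.9-fold higher number from compound 2 to compound 3 (0.46 log units; beyond the scatter), a rise in the number that is modest but beyond the scatter, on exchanging pyridin-2-yl for 3-nitrophenyl on a double-bonded chain carbon bound to a double-bonded chain carbon.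

Compound 4 `COc1cc(OC)c2c(=O)c(OCCCOc3ccccc3/C=C/C(=O)/C=C/c3scnc3C)c(-c3cc(OC)c(OC)c(OC)c3)oc2c1` carries the change (4-methyl-1,3-thiazol-5-yl in place of 3-nitrophenyl on a double-bonded chain carbon bound to a double-bonded chain carbon). Cut one bond further out, the same difference reads 2-(3-nitrophenyl)ethenyl to 2-(4-methyl-1,3-thiazol-5-yl)ethenyl. The step from compound 2 to compound 3 bears on this directly: it also swapped one ring for another at the same place, and the entering group of compound 4 is again a ring with hetero atoms, as in compound 2. Among the compounds with values here, that step was modest, so a step of similar size in this assay, this time downward, is expected, though with no second example the direction is not secure. Compound 4 is therefore expected at 5000 nM, with a range of 2000 nM to 14000 nM. The estimate corresponds to an expected step of a 1.8-fold lower number from compound 3 to compound 4 (0.26 log units; within the scatter).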

Compound 4, half-maximal inhibitory concentration: 7210 nM
Compound 4: the middle estimate sits 1.4-fold (0.16 log units) below what was measured; the measured number falls inside the stated range.
By their numbers in this assay, from the lowest: compound 2; then compounds 4 and 3 (each within the scatter of the next); then compound 1.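

In this assay, the exchange on a double-bonded chain carbon bound to a double-bonded chain carbon gives a 1.3-fold lower number from compound 3 to compound 4 (0.11 log units; within the scatter) and so leaves 3-nitrophenyl and 4-methyl-1,3-thiazol-5-yl unresolved, although the two differ in ring size, in hetero atoms and in heavy atoms, with 9 leaving and 6 entering. Pyridin-2-yl now stands apart from two different rings at this place, since a 2.3-fold higher number from compound 2 to compound 4 (0.36 log units; beyond the scatter) comes on top of a 2.9-fold higher number from compound 2 to compound 3 (0.46 log units; beyond the scatter) and both steps lie beyond the scatter, so a ring with hetero atoms does not by itself match compound 2, and compound 4 is the case that goes against any such pattern. Nothing available accounts for either step.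

Open, going by these compounds, is whether a non-aromatic group at this place, such as an open-chain amine or a carboxylic acid, would stay in the same range as these aromatic rings. Also open, on these data alone, is whether the advantage of pyridin-2-yl extends to pyridin-4-yl, and whether the ring of compound 4 behaves the same without its methyl group.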